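The source may hold more compounds than are shown below. What is called first, only, known or untested is meant among the compounds shown, and "the series" means these compounds.

Measured so far: compound 1 `C[C@@H](Nc1nccc(Cl)c1NC(=O)CC#N)c1ccc(-c2cccc(F)c2C(F)(F)F)cc1` and compound 2 `COC(=O)c1ccc(Cl)cc1-c1ccc([C@@H](C)Nc2nccc(Cl)c2NC(=O)CC#N)cc1`.

In an in vivo ADME assay on the whole organism (strain Sprague-Dawley) for pharmacokinetics, with Rattus norvegicus as the target, at a dose of 2 mg/kg by the intravenous route (a lower number here means slower removal, a higher number faster removal of the compound), compound 1 gives 36 mL/min/kg. Compound 2 gives 25 mL/min/kg in this assay. Compound 1 thus has the higher of the two numbers, though the step of a 1.4-fold lower number from compound 1 to compound 2 (0.16 log units; within the scatter) lies within the scatter. Compound 3 `Cc1nc(-c2c(F)cccc2-c2ccc([C@@H](C)Nc3nccc(Cl)c3NC(=O)CC#N)cc2)no1` is compound 1 with 5-methyl-1,2,4-oxadiazol-3-yl in place of trifluoromethyl on an aromatic carbon. Within the data shown here, the only step available, from compound 1 to compound 2, swapped the whole outer aryl group and stayed within the scatter; the change to compound 3 is smaller. Compound 3 is therefore expected to show a 1.2-fold lower number from compound 1 to compound 3 (0.08 log units; within the scatter). Compound 3 is estimated at 30 mL/min/kg, within 15 mL/min/kg to 60 mL/min/kg.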

Compound 3, clearance: 4.9 mL/min/kg
Estimate against measurement, compound 3: 6.1-fold (0.79 log units) above, and the stated range ends above it.
By their numbers in this assay, from the lowest: compound 3; then compounds 2 and 1 (each within the scatter of the next).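

In this assay, among these compounds, putting 5-methyl-1,2,4-oxadiazol-3-yl in place of trifluoromethyl gives a 7.3-fold lower number from compound 1 to compound 3 (0.87 log units; beyond the scatter), the only step so far beyond the scatter. A change at this one aromatic carbon, ortho to a fluoro group, can therefore shift the number more than replacing the whole outer aryl group did in compound 2. Nothing available explains this shift.

On these data alone, whether the result depends on this particular ring or simply on losing trifluoromethyl remains open. A 1,3,4-oxadiazole, a plain methyl or an amine at this carbon would help separate the two.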